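Alkoxy and alkyl variation on a shared dioxide core

A few compounds are considered here, and "the series" means these few. Any claim that something is new, unique, unknown or untested is made for them only; others in the source may bear on it.

Measured compounds:
- compound 1, `CCc1ccc2c(c1)[n+]([O-])c(NCCN1CCCCC1)n[n+]2[O-]`: 1500 nM
- compound 2, `CC(C)c1ccc2c(c1)[n+]([O-])c(NCCN1CCCCC1)n[n+]2[O-]`: 2700 nM
- compound 3, `CCOc1ccc2c(c1)[n+]([O-])c(NCCN(C)C)n[n+]2[O-]`: 2600 nM

The three measured compounds were tested in a functional assay on HT-29 cells (Homo sapiens) for cytotoxicity, with a stated time of 4 h; on this read-out lower numbers stand for stronger inhibition and higher numbers for weaker inhibition. Compound 1 gives 1500 nM in this assay, and compound 2 gives 2700 nM. The two differ by methyl in place of hydrogen on a saturated chain carbon bound to an aromatic carbon and a saturated chain carbon, and the step is a 1.8-fold higher number from compound 1 to compound 2 (0.26 log units; within the scatter). Compound 3 gives 2600 nM in this assay; it stands close to compound 2 and to compound 1, and all three numbers lie within the scatter of one another, so no order among them can be read.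

Compound 3 and compound 1 differ in more than one place, and the difference between the two cores is not broken down here.

Compound 4, `CC(C)Oc1ccc2c(c1)[n+]([O-])c(NCCN(C)C)n[n+]2[O-]`, is not yet measured in this assay. It differs from compound 3 by methyl in place of hydrogen on a saturated chain carbon bound to an oxygen on an aromatic ring and a saturated chain carbon. This is the same kind of change as that from compound 1 to compound 2, but not the same: in the earlier pair the carbon carrying the new methyl is bound to an aromatic carbon and a saturated chain carbon, whereas in compound 4 it is bound to an oxygen on an aromatic ring and a saturated chain carbon. Within the data shown here, the only guide is the earlier step, a 1.8-fold higher number from compound 1 to compound 2 (0.26 log units; within the scatter), which stayed within the scatter. On that basis a step of about a 1.5-fold higher number from compound 3 to compound 4 (0.18 log units; within the scatter) is expected from compound 3 to compound 4, a small shift only. Compound 4 is thus estimated to give about 3900 nM in this assay, with a range of 1500 nM to 10000 nM expected.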

Compound 4, half-maximal inhibitory concentration: 5000 nM
Compound 4: the middle estimate sits 1.3-fold (0.11 log units) below what was measured; measured number inside the range.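

In this assay, the change from ethoxy to isopropoxy gives a 1.9-fold higher number from compound 3 to compound 4 (0.28 log units; within the scatter), so the added methyl on this core leaves the number within the scatter of its starting point. Set beside the change from ethyl to isopropyl on the core of compound 1, the two steps agree, and in this series the change carries from one core to the other with no difference that can be read: the same change on two cores in this assay, a 1.8-fold higher number (0.26 log units; within the scatter) from compound 1 to compound 2 and a 1.9-fold higher number (0.28 log units; within the scatter) from compound 3 to compound 4, 1.1-fold (0.03 log units) apart, within the scatter of two such steps This agreement rests on two pairs only, and since each step lies within the scatter, neither pair shows that the added methyl has a real effect on the read-out, nor does the agreement show that the same step would appear on any further core, especially as the cores of compound 1 and compound 3 differ in more than one place.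

The compounds shown leave open whether a larger alkyl group such as tert-butyl, or a longer chain such as propoxy or butoxy, in the same place would move the number beyond the scatter. They also leave open how a group of another kind there, such as an amine or a carboxylic acid, would compare with ethoxy and isopropoxy on the core of compound 3.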